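A Methoxy Group Removed Twice: Predicting Compound 4

The source may report more compounds than this note shows. Statements on the series, on what has been measured and on what is new or still open speak of the compounds shown alone.

Compound 1 `COc1ccc(C2=NN(C(=O)CBr)C(c3c(Cl)cccc3Cl)C2)cc1OC` was tested in a functional assay on the whole organism (strain albino) for inhibition, with Rattus norvegicus as the target, read by paw edema, with stated times of 30 min and 1 h, at a dose of 100 mg/kg by the oral route (on this read-out lower numbers stand for less inhibition and higher numbers for more inhibition at the one dose given (going by the name of the read-out)), where compound 1 gives 48%. Compound 2 `COc1ccc(C2=NN(C(=O)CBr)C(c3c(Cl)cccc3Cl)C2)cc1` differs from it by hydrogen in place of methoxy on an aromatic carbon, and in this assay compound 2 gives 43%, a step of a number 5 percentage points lower from compound 1 to compound 2 (within the scatter). Compound 3 `COc1ccc(C2=NN(C(=O)CO[N+](=O)[O-])C(c3c(Cl)cccc3Cl)C2)cc1OC` carries a different core, set apart from compound 1 by nitrooxy in place of bromo on a saturated chain carbon bound to a carbonyl carbon; in this assay compound 3 gives 40%, a step of a number 8 percentage points lower from compound 1 to compound 3 (within the scatter). Compound 4 `COc1ccc(C2=NN(C(=O)CO[N+](=O)[O-])C(c3c(Cl)cccc3Cl)C2)cc1`, not yet measured, differs from compound 3 by hydrogen in place of methoxy on an aromatic carbon, the same change that separates compound 1 from compound 2. Because the earlier step of a number 5 percentage points lower from compound 1 to compound 2 (within the scatter) stayed within the scatter, compound 4 is expected to show a similar small step, a number 4 percentage points lower from compound 3 to compound 4 (within the scatter). The estimate for compound 4 is therefore 36%, expected to fall between 26% and 46%.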

Compound 4, a percentage reported as inhibition, in the whole organism at one dose (the size of the read-out at that dose, not a potency): 34%
The estimate for compound 4 lay 2 percentage points above the measured number; the measured number falls inside the stated range.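

Replacing the 3,4-dimethoxyphenyl with 4-methoxyphenyl in this assay gives a number 6 percentage points lower from compound 3 to compound 4 (within the scatter), and this step agrees with the earlier one: the same change on two cores in this assay, a number 5 percentage points lower (within the scatter) from compound 1 to compound 2 and a number 6 percentage points lower (within the scatter) from compound 3 to compound 4, 1 percentage points apart, within the scatter of two such steps. Nitrooxy in place of bromo gives a number 9 percentage points lower from compound 2 to compound 4 (within the scatter), and this change also carries over: the same change on two cores in this assay, a number 8 percentage points lower (within the scatter) from compound 1 to compound 3 and a number 9 percentage points lower (within the scatter) from compound 2 to compound 4, 1 percentage points apart, within the scatter of two such steps. Within the data shown here, all of these steps lie within the scatter, so the agreement shows only that each change stays small on both cores, not that either change moves the read-out in a real or fixed direction.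

The compounds shown leave open how a hydroxy group or a longer alkoxy chain would read on the aromatic ring. They also leave open how an amine or a carboxylic acid would read in place of bromo or nitrooxy on the chain carbon.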